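Urea substituent exchange in a reporter inhibition series

The source may hold more compounds than are shown below. What is called first, only, known or untested is meant among the compounds shown, and "the series" means these compounds.

Measured compounds:
compound 1 `O=C(NC1CCS(=O)(=O)CC1)N1CCC(c2nc(-c3ccc4ccccc4n3)no2)CC1`: 360 nM
compound 2 `Cn1c(-c2noc(C3CCN(C(=O)NC4CCS(=O)(=O)CC4)CC3)n2)nc2ccccc21`: 350 nM

In a functional assay on Shh Light II cells (Mus musculus) for inhibition, read by a luciferase reporter (on this read-out lower numbers stand for stronger inhibition and higher numbers for weaker inhibition), compound 1 gives 360 nM and stands at the top of the two numbers shown, yet a 1.0-fold lower number from compound 1 to compound 2 (0.01 log units; within the scatter) lies within the scatter, so compounds 1 and 2 cannot be separated on these data.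

Compound 3 `O=C(Nc1cccc2cccnc12)N1CCC(c2nc(-c3ccc4ccccc4n3)no2)CC1` differs from compound 1 by quinolin-8-yl in place of 1,1-dioxothian-4-yl on an amide-type nitrogen. Among the measured compounds shown here, the single measured step, a 1.0-fold lower number from compound 1 to compound 2 (0.01 log units; within the scatter), alters a different position, so no measured step bears on this change and there is no precedent for its size or direction. The step is expected to stay modest, a 1.1-fold higher number from compound 1 to compound 3 (0.05 log units; within the scatter), with a wide range. Compound 3 is therefore estimated at 400 nM, between 100 nM and 1600 nM.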

Compound 3, half-maximal inhibitory concentration: 1400 nM
Beside the measured number, compound 3's estimate is 3.5-fold (0.54 log units) below it; measured number inside the range.
By their numbers in this assay, from the lowest: compounds 2 and 1 (each within the scatter of the next); then compound 3.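

With the 1,1-dioxothian-4-yl group on the amide-type nitrogen replaced by quinolin-8-yl, this assay shows a 3.9-fold higher number from compound 1 to compound 3 (0.59 log units; beyond the scatter). This position therefore affects the read-out, and the exchange weakens inhibition, whereas the earlier step at a different position could not be told from scatter. No available data explain this loss.

As far as these compounds go, it remains open whether the loss follows from the arrival of quinolin-8-yl or the departure of 1,1-dioxothian-4-yl; a cyclohexyl or phenyl group on the same nitrogen would help separate the two. Also open, from the compounds shown here alone, is whether the exchange behaves alike on compound 2.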